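Compound 1 to compound 3: one more nitro group

The source may hold more compounds than are shown below. What is called first, only, known or untested is meant among the compounds shown, and "the series" means these compounds.

Compound 1 `O=c1[nH]c(SCc2ccccc2[N+](=O)[O-])nc2ccccc12` gives > 64000 nM here
Compound 2 `O=c1[nH]c(SCc2ccc([N+](=O)[O-])cc2[N+](=O)[O-])nc2ccccc12` gives > 64000 nM here

In an ADME assay on MRC5 cells (Homo sapiens) for cytotoxicity, read by neutral red uptake (on this read-out higher numbers stand for lower toxicity in this test and lower numbers for higher toxicity in this test), compound 1 gives > 64000 nM as a limit of the assay and not a number. Compound 2 likewise gives > 64000 nM as a limit. Compound 1 therefore stands with compound 2 at the top of the measurable range (the limit of > 64000 nM in this assay, at which 2 of the 2 values shown sit).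

Compound 3 (`O=c1[nH]c(SCc2c([N+](=O)[O-])cccc2[N+](=O)[O-])nc2ccccc12`) is not yet measured. Its difference from compound 1 is a single change (nitro in place of hydrogen on an aromatic carbon). Going by the values given here, the only measured step of this kind, also nitro in place of hydrogen on an aromatic carbon, has no readable size (a step that the two limits leave unreadable from compound 1 to compound 2). In this assay no step beyond the usual scatter is therefore expected, and no direction can be assigned. The estimated step is small (a number no higher from compound 1 to compound 3 (the limit leaves the size open)). The estimate for compound 3 is 64000 nM with an expected range from 30000 nM to 128000 nM in this series.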

Compound 3, half-maximal cytotoxic concentration: > 64000 nM
Compound 3: a limit, no number (the forecaster's own chance of this, stated with the estimate: 75%); the middle value lies on the limit itself.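

No step can be read between compound 1 and compound 3 in this assay, as each result is a limit of the assay and not a number: the limit of > 64000 nM in this assay, at which 3 of the 3 values shown sit.

The compounds shown leave open whether an added nitro group changes toxicity in this test, and at what concentration any of the three becomes toxic.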